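A few compounds are considered here, and "the series" means these few. Any claim that something is new, unique, unknown or untested is made for them only; others in the source may bear on it.

Measured compounds:
compound 1, `COc1cc2ncnc(-n3nc(Nc4ccc(N5CCN(C6CC7CCC6C7)CC5)c(Cl)c4)nc3N)c2cc1OC`, 27 L/kg in an ADME assay on the whole organism (strain Sprague-Dawley) for pharmacokinetics, with Rattus norvegicus as the target; a higher number here means that more of the compound sits outside the plasma, a lower number that more of the compound stays in the plasma
compound 2, `Cc1nc(-n2nc(Nc3ccc(N4CCN(C5CC6CCC5C6)CC4)cc3)nc2N)c2ccccc2n1`, "not determined" (no result reported) in this assay

Among the compounds with values here, compound 1 is the only member of this set with a number: in this assay compound 1 gives 27 L/kg, a large value that places most of the compound outside the plasma. Compound 2 shares the piperazine-linked bicyclic amine and the aminotriazole core of compound 1, but for compound 2 this assay is recorded only as "not determined" (no result reported), so compound 2 has no single number on which to stand, and nothing can be said of how it compares with compound 1.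

Compound 3, `Nc1nc(Nc2ccc(N3CCN(C4CC5CCC4C5)CC3)cc2)nn1-c1nccc2ccccc12`, is the next compound to be measured in this assay. It differs from compound 2 in one place: isoquinolin-1-yl in place of 2-methylquinazolin-4-yl on an aromatic nitrogen. Within the data shown here, no measured pair in this set shows what such a change does in this assay, so no direction can be read from the data, and the step from compound 2 to compound 3 is expected to be none beyond the scatter. With compound 1 at 27 L/kg as the only anchor, compound 3 is estimated at 20 L/kg, with a range from 7 L/kg to 55 L/kg.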

Compound 3, volume of distribution at steady state: 8.8 L/kg
For compound 3 the middle estimate is 2.3-fold (0.36 log units) above the measured one, and the stated range covers the measured number.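

Within the data shown here, compound 2 has no single number in this assay, so no step from compound 2 to compound 3 can be read, even with compound 3 at 8.8 L/kg. The compounds shown leave open what isoquinolin-1-yl in place of 2-methylquinazolin-4-yl does to this read-out. No available information bears on this result.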